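A few compounds are considered here, and "the series" means these few. Any claim that something is new, unique, unknown or untested is made for them only; others in the source may bear on it.

Measured compounds and their values:

Compound 1, `O=C(N/N=C/c1ccc(F)cc1)c1ccc(O[C@@H]2O[C@H](CO)[C@@H](O)[C@H](O)[C@H]2O)cc1`: 9.91%
Compound 2, `O=C(N/N=C/c1cccc(Cl)c1)c1ccc(O[C@@H]2O[C@H](CO)[C@@H](O)[C@H](O)[C@H]2O)cc1`: 5.02%

Both compounds share the same core and differ only in the halogen on the ring attached to the carbon that carries a double bond to nitrogen. In a functional assay on MDA-MB-231 cells (Homo sapiens) for inhibition, read by MTT assay, with a stated time of 24 h, tested at 100 uM (a higher number here means more inhibition at the concentration tested (going by the name of the read-out), a lower number less inhibition), compound 2 gives 5.02%. Among the compounds with values here, its only neighbour on the numbers is compound 1, and the step of a number 4.9 percentage points lower from compound 1 to compound 2 (within the scatter) is within the scatter, so the two compounds cannot be told apart on this read-out; both show little inhibition at the concentration tested.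

Compound 3, `O=C(N/N=C/c1ccccc1)c1ccc(O[C@@H]2O[C@H](CO)[C@@H](O)[C@H](O)[C@H]2O)cc1`, has not yet been measured. It differs from compound 2 in one place: hydrogen in place of chloro on an aromatic carbon

Within the data shown here, the only measured step that touches this part of the molecule is the one from compound 1 to compound 2, where swapping one halogen for another at a different place gave a change within the scatter. Among the measured compounds shown here, no measured step removes a halogen outright. Taking the two values together, any step in this assay from compound 2 to compound 3 is expected to be small and within the scatter, a number 2 percentage points higher from compound 2 to compound 3 (within the scatter). Compound 3 is therefore estimated at 7%, between 0% and 20%.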

Compound 3, a percentage reported as inhibition, at one concentration (the size of the read-out at that concentration, not a potency): 3.56%
For compound 3 the middle estimate is 3.4 percentage points above the measured one; the range from low to high includes it.
By their numbers in this assay, from the lowest: compounds 3, 2 and 1 (each within the scatter of the next).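

In this assay, putting hydrogen in place of chloro on this aromatic carbon gives a number 1.5 percentage points lower from compound 2 to compound 3 (within the scatter), and putting hydrogen in place of fluoro gives a number 6.4 percentage points lower from compound 1 to compound 3 (within the scatter). Within the data shown here, the earlier compounds compared only one halogen-bearing ring with another, whereas these steps add a ring with no halogen at all, and the three compounds still cannot be told apart on this read-out. A halogen on this ring is therefore not needed for the small inhibition seen here, and nothing available bears on what lies behind these numbers.

The compounds shown carry only hydrogen, fluoro or chloro on this ring, so it remains open whether a different group there, such as an amine, a carboxylic acid or a longer chain, would shift the number by more than the scatter. Because each compound is reported at a single concentration, the values also leave open how potent any of them is, and whether changes elsewhere on the shared core would matter more than changes on this ring.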